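From compound 2 to compound 3: a halogen swap

The source may hold more compounds than are shown below. What is called first, only, known or untested is meant among the compounds shown, and "the series" means these compounds.

Compound 1 `O=C(Nc1ccc2[nH]c(=O)oc2c1)C(=O)N1CCN(c2ccc(F)c(F)c2)CC1`: 4 mL/min/kg
Compound 2 `O=C(Nc1ccc2[nH]c(=O)oc2c1)C(=O)N1CCN(c2cc(F)cc(F)c2)CC1`: "not determined" (no result reported)

In an ADME assay on the whole organism (Rattus norvegicus, strain Sprague-Dawley) for pharmacokinetics, using cassette dosing, at a dose of 0.5 mg/kg by the intravenous route (a lower number here means slower removal, a higher number faster removal of the compound), compound 2 has no number to stand on, as its entry reads "not determined" (no result reported). Among the compounds with values here, the only measured reference is compound 1, at 4 mL/min/kg. Compound 3 `O=C(Nc1ccc2[nH]c(=O)oc2c1)C(=O)N1CCN(c2ccc(F)c(Cl)c2)CC1` keeps the shared core and differs from compound 2 on an amine nitrogen in a ring: 3-chloro-4-fluorophenyl in place of 3,5-difluorophenyl on an amine nitrogen in a ring. Within the data shown here, no measured step shows what such a swap does, so the expectation is modest: no difference from compound 1 beyond the scatter, and no clear direction. The estimate for compound 3 is an expected 5 mL/min/kg, with a range from 2.5 mL/min/kg to 11 mL/min/kg.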

Compound 3, clearance: 18.3 mL/min/kg
Estimate against measurement, compound 3: 3.7-fold (0.56 log units) below; measured number outside the range, above it.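

In this assay, chloro in place of fluoro on an aromatic carbon gives a 4.6-fold higher number from compound 1 to compound 3 (0.66 log units; beyond the scatter) and so shows that this single halogen swap on the phenyl ring can speed removal from the body by more than the usual scatter. Nothing shown here explains this rise. The step from compound 2 cannot be read, since compound 2 has no number. Still open, going by these compounds, is how a bromo, methyl or nitrile group on that same aromatic carbon would compare with chloro and fluoro.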